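A few compounds are considered here, and "the series" means these few. Any claim that something is new, unique, unknown or untested is made for them only; others in the source may bear on it.

Working notes on the series. The shared core is the same in all four compounds; the variable part is the aryl group on the amide-type nitrogen and the thiophene attached to the core.

Compound 2 `CC(C)n1ncc2c(C(=O)Nc3ccncc3)cc(-c3cccs3)nc21` gives 6300 nM in an ADME assay on LLC-MK2 cells (Macaca mulatta) for cytotoxicity, read by spectrophotometry and crystal violet staining, with a stated time of 4 days (on this read-out higher numbers stand for lower toxicity in this test and lower numbers for higher toxicity in this test), the lowest of the two numbers here. Compound 1 `CC(C)n1ncc2c(C(=O)Nc3ccccn3)cc(-c3ccsc3)nc21` gives 25000 nM in this assay, a higher number than compound 2. Compound 3 `CC(C)n1ncc2c(C(=O)Nc3ccc(F)cc3)cc(-c3ccsc3)nc21` sits at a limit of this assay, > 200000 nM, and no number is known for it.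

The change from compound 2 to compound 4 `CC(C)n1ncc2c(C(=O)Nc3cc(F)ccc3F)cc(-c3cccs3)nc21` is 2,5-difluorophenyl in place of pyridin-4-yl on an amide-type nitrogen. For the measured compounds named here, the one step that bears on it is an at least 8.0-fold higher number from compound 1 to compound 3 (0.90 log units; beyond the scatter), where a fluorophenyl also replaced a pyridyl on the amide-type nitrogen and the number went up, reaching the limit (the limit of > 200000 nM in this assay, at which 1 of the 3 values shown sits). A step in the same direction is therefore expected for compound 4 in this assay, though its size is uncertain since the template step is itself only a lower bound. The estimate for compound 4 is 60000 nM, between 15000 nM and 200000 nM, which means an expected step of a 9.5-fold higher number from compound 2 to compound 4 (0.98 log units; beyond the scatter).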

Compound 4, half-maximal cytotoxic concentration: 100000 nM
For compound 4 the middle estimate is 1.7-fold (0.22 log units) below the measured one; the range from low to high includes it.
By their numbers in this assay, from the lowest: compound 2; then compound 1; then compound 4. At a limit, above all of these: compound 3.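

For the compounds shown here, the step from pyridyl to fluorophenyl on the amide-type nitrogen had so far been seen only as a lower bound, an at least 8.0-fold higher number from compound 1 to compound 3 (0.90 log units; beyond the scatter). Compound 3 is at a limit, so that step gave no size: the limit of > 200000 nM in this assay, at which 1 of the 4 values shown sits. Compound 4 gives the change a measured size, a 16-fold higher number from compound 2 to compound 4 (1.20 log units; beyond the scatter), in a large step that goes the same way as the earlier one, with a different pyridyl leaving, a different fluorophenyl entering and the thiophene attachment of compound 2, and neither step in this assay goes against this direction.

From the compounds shown here alone, it remains open how much of the step goes with the loss of the pyridine nitrogen and how much with the gain of fluorine, and an unsubstituted phenyl on the amide-type nitrogen would separate the two. Also open, going by these compounds, is whether a carboxylic acid or an amine on that aryl ring would keep the higher number.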